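This account rests on a few compounds, and the source may have more. Where it says the series, first, only, none or still open, it means among the compounds named here.

Measured compounds:
compound 1, `COc1cc(COc2cc(N)c(Cl)cc2C(=O)CCCCN2CCCCC2)cc(OC)c1`, with 8.5
compound 2, `COc1cc(COc2cc(N)c(Cl)cc2C(=O)CCCCN2CCC(C(N)=O)CC2)cc(OC)c1`, with 8.4

In a functional assay for antagonist activity at 5-hydroxytryptamine receptor 4 (Rattus norvegicus) (on this read-out higher numbers stand for higher potency (the scale is a negative logarithm) and lower numbers for lower potency), compound 1 gives 8.5, and compound 2 gives 8.4. The two sit within the scatter of each other, so compound 2 is not set apart from compound 1. Among the measured compounds shown here, the one known step, a number 0.10 log units lower from compound 1 to compound 2 (within the scatter), shows that placing a carbamoyl group on the saturated ring carbon left potency essentially unchanged.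

Compound 3, `COc1cc(COc2cc(N)c(Cl)cc2C(=O)CCCCN2CCC(NC(N)=O)CC2)cc(OC)c1`, is not yet measured. It differs from compound 2 in one place: ureido in place of carbamoyl on a saturated ring carbon. For the measured compounds named here, no measured step covers this exact exchange. Going by the values given here, the only related information is the step from compound 1 to compound 2, which was within the scatter, so a step of similar small size is expected here, with no clear direction. The expected change is a number 0.10 log units lower from compound 2 to compound 3 (within the scatter). Compound 3 is therefore estimated at 8.3, with a range from 7.7 to 8.9.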

Compound 3, negative logarithm of the antagonist equilibrium constant: 8.5
Estimate against measurement, compound 3: 0.20 log units below; the measured number falls inside the stated range.
By their numbers in this assay, from the lowest: compounds 2, 1 and 3 (each within the scatter of the next).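

In this assay, the exchange on this saturated ring carbon gives a number 0.10 log units higher from compound 2 to compound 3 (within the scatter) and set against the unsubstituted ring, the ureido group gives no change at the digits printed from compound 1 to compound 3 (within the scatter) and so matches the carbamoyl result. Among the compounds shown here, the earlier pair showed only that one group could sit at this carbon, three ring bonds from the ring nitrogen, with no step beyond the scatter; now two different groups have done so, and swapping one for the other also stays within the scatter. Nothing available here explains why the numbers stay so close.

From the compounds shown here alone, all three compounds share the same core and chain, so it remains open whether this holds for other groups at this carbon. A primary amine, a carboxylic acid or a longer chain ending in a ureido group could show where the position stops accepting change.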